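Carboxy-aryl swap on a piperidine series probed for kinase activation

A few compounds are considered here, and "the series" means these few. Any claim that something is new, unique, unknown or untested is made for them only; others in the source may bear on it.

Compound 1 `OC[C@@H](O[C@H]1CCCN(Cc2ccccc2Cc2nnco2)[C@H]1c1ccccc1)c1cc(Cl)cc(Cl)c1`: 3700 nM
Compound 2 `O=C(O)c1ccc(CN2CCC[C@H](OCc3cc(Cl)cc(Cl)c3)[C@@H]2c2ccccc2)s1`: 76000 nM
Compound 3 `O=C(O)c1ccc(CN2CCC[C@H](O[C@H](CO)c3cc(Cl)cc(Cl)c3)[C@@H]2c2ccccc2)cc1`: 11000 nM

In an assay on isolated protein for activation of cGMP-dependent protein kinase 1 (Homo sapiens), read by ADP-Glo, with stated times of 120 min and 40 min (a lower number here means that less compound is needed, a higher number that more compound is needed for the effect), compound 2 gives the highest number of the three, standing a 3.0-fold higher number from compound 1 to compound 3 (0.47 log units; beyond the scatter) apart from neither directly; compound 3 gives 11000 nM and compound 1 gives 3700 nM. Compound 4 `O=C(O)c1cncc(CN2CCC[C@H](OCc3cc(Cl)cc(Cl)c3)[C@@H]2c2ccccc2)c1` carries the change (5-carboxypyridin-3-yl in place of 5-carboxythiophen-2-yl on a saturated chain carbon bound to an amine nitrogen in a ring). Among the measured compounds shown here, the only step available, a 3.0-fold higher number from compound 1 to compound 3 (0.47 log units; beyond the scatter), concerns the same place but a different pair of groups, so it bears on this change only loosely. For the measured compounds named here, with no direct precedent, compound 4 is expected to show a small shift, a 1.4-fold lower number from compound 2 to compound 4 (0.14 log units; within the scatter), toward a lower number. The estimate for compound 4 is 55000 nM, with a range from 15000 nM to 200000 nM.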

Compound 4, half-maximal effective concentration: 117000 nM
The estimate for compound 4 lay 2.1-fold (0.33 log units) below the measured number; low and high end bracket the measured number.
By their numbers in this assay, from the lowest: compound 1; then compound 3; then compounds 2 and 4 (each within the scatter of the next).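

In this assay, 5-carboxypyridin-3-yl in place of 5-carboxythiophen-2-yl on a saturated chain carbon bound to an amine nitrogen in a ring gives a 1.5-fold higher number from compound 2 to compound 4 (0.19 log units; within the scatter), so these two carboxy-bearing groups cannot be told apart here. The earlier step at this place, a 3.0-fold higher number from compound 1 to compound 3 (0.47 log units; beyond the scatter), lay beyond the scatter, whereas this one does not. No measurement shown speaks to why the two groups read alike. Going by these compounds, it remains open whether an amide or a nitrile in place of the carboxylic acid would shift the number. On these data alone, the effect of the hydroxymethyl-bearing ether of compound 3 on the 5-carboxypyridin-3-yl series also remains open.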